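The compounds below may be only part of what the source reports. "The series", "measured", "known", "first", "only" and "open" are said of these compounds alone.

Compound 1 `CCOC(=O)C1=C(Nc2ccc(F)cc2)S/C(=C\c2ccc[nH]2)C1=O` opens the series considered here. In a functional assay on K562 cells (Homo sapiens) for inhibition, read by MTT assay, with a stated time of 72 h (a higher number here means a weaker inhibitor, a lower number a stronger inhibitor), compound 1 gives only a limit, > 100000 nM. Compound 2 `CCOC(=O)C1=C(Nc2cccc(F)c2)S/C(=C\c2ccc[nH]2)C1=O` carries 3-fluorophenyl in place of 4-fluorophenyl on the amine nitrogen; in this assay compound 2 again gives only a limit, > 100000 nM. Compound 3 `CCOC(=O)C1=C(Nc2cccc(C(F)(F)F)c2)S/C(=C\c2ccc[nH]2)C1=O` has trifluoromethyl in place of fluoro on an aromatic carbon, and in this assay compound 3 likewise gives only a limit, > 100000 nM. The step that the two limits leave unreadable from compound 1 to compound 2 and the step that the two limits leave unreadable from compound 2 to compound 3 cannot be sized because of the limit of > 100000 nM in this assay, at which 3 of the 3 values shown sit. Compound 3 therefore stands at the same limit as the other two, with no number that would rank it.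

Compound 4 `CCOC(=O)C1=C(Nc2cccc([N+](=O)[O-])c2)S/C(=C\c2ccc[nH]2)C1=O` differs from compound 3 by nitro in place of trifluoromethyl on an aromatic carbon, a nitro in place of trifluoromethyl on an aromatic carbon. Neither recorded step bears directly on this change, and neither gives a readable size in any direction. In this assay compound 4 is expected to remain at the limit, the expected step of a number no higher from compound 3 to compound 4 (the limit leaves the size open) being of no readable size. The estimate for compound 4 in this assay is 100000 nM, with a range from 30000 nM to 300000 nM.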

Compound 4, half-maximal inhibitory concentration: 7200 nM
Compound 4: middle estimate off by 14-fold (1.14 log units), on the high side; the whole stated range lies above it.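

The aromatic carbon that carried trifluoromethyl or fluoro can move the read-out in this assay: nitro there gives an at least 13-fold lower number from compound 3 to compound 4 (1.14 log units; beyond the scatter), and against fluoro it gives an at least 13-fold lower number from compound 2 to compound 4 (1.14 log units; beyond the scatter). The change of the whole group on the amine nitrogen gives an at least 13-fold lower number from compound 1 to compound 4 (1.14 log units; beyond the scatter), so among the four compounds only 3-nitrophenyl yields a number rather than a limit. Each of these steps is a bound and not a full size, as one end of each is a limit: the limit of > 100000 nM in this assay, at which 3 of the 4 values shown sit.

The compounds shown leave open whether nitro on another carbon of the ring would give a number, and how a nitrile, an amine or a carboxylic acid on this carbon would read. As far as these compounds go, the true size of all three steps also remains open.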